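This account rests on a few compounds, and the source may have more. Where it says the series, first, only, none or still open, it means among the compounds named here.

Measured compounds and values:

compound 1 `CNc1cc(Nc2ncc3c(n2)N(C)C(=O)N(c2cc(NC(=O)c4cccc(C(F)(F)F)c4)ccc2C)C3)ccc1C` — > 10000 nM
compound 2 `Cc1ccc(Nc2ncc3c(n2)N(C)C(=O)N(c2cc(NC(=O)c4cccc(C(F)(F)F)c4)ccc2C)C3)cc1N(C)C` — > 10000 nM
compound 3 `CNc1nc(Nc2ccc(C)c(N)c2)ncc1C(=O)Nc1cc(NC(=O)c2cccc(C(F)(F)F)c2)ccc1C` — > 10000 nM

In an ADME assay on BaF3 cells (Mus musculus) for antiproliferative activity, read by CellTiter-Glo and CCK-8 assay, with a stated time of 72 h (on this read-out higher numbers stand for weaker inhibition of growth and lower numbers for stronger inhibition of growth), compound 1 gives > 10000 nM, which is a limit of the assay and not a number. In this assay compound 2 gives > 10000 nM, again a limit. In this assay compound 3 gives > 10000 nM, also a limit. The common feature is the limit of > 10000 nM in this assay, at which 3 of the 3 values shown sit.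

Compound 2 differs from compound 1 by methyl in place of hydrogen on a nitrogen on an aromatic ring. The corresponding step, a step that the two limits leave unreadable from compound 1 to compound 2, cannot be sized, since both ends sit at the limit.

Compound 4 `Cc1ccc(Nc2ncc(C(=O)Nc3cc(NC(=O)c4cccc(C(F)(F)F)c4)ccc3C)c(N(C)C)n2)cc1N` is not yet measured. It differs from compound 3 by methyl in place of hydrogen on a nitrogen on an aromatic ring, and the surroundings of the place are the same as for the change from compound 1 to compound 2, so this is the same change made a second time, now on the core of compound 3. How the core of compound 3 differs from the core of compound 1 is not broken down here.

The expected step is a step that the limit leaves unreadable from compound 3 to compound 4; this rests on the limit of > 10000 nM in this assay, at which 3 of the 3 values shown sit, and on the fact that compound 3 itself is known only as a limit, > 10000 nM, so the most that can be expected is that compound 4 stays in the same region. Compound 4 is therefore estimated at 20000 nM in this assay, with the likely range from 7000 nM to 60000 nM, and a numerical read-out is not expected.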

Compound 4, concentration for 50% growth inhibition: > 10000 nM
Compound 4: a limit, no number; the forecaster's own chance of this, stated with the estimate: 85%; the middle value is on the limit's open side.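

No step can be read between compound 3 and compound 4, as each is known only as a limit and not as a number. The compounds shown leave open how strongly any of them inhibits growth in this assay, and whether methylamino or dimethylamino makes any difference on either core, with one limit shared throughout: the limit of > 10000 nM in this assay, at which 4 of the 4 values shown sit.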